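Pyrazole methylation step in the chemokine receptor series

A few compounds are considered here, and "the series" means these few. Any claim that something is new, unique, unknown or untested is made for them only; others in the source may bear on it.

Measured in an assay on blood for inhibition of C-X-C chemokine receptor type 3 (Homo sapiens), with a stated time of 30 min; on this read-out higher numbers stand for weaker inhibition and lower numbers for stronger inhibition:
compound 1 `CCOc1ncc(-c2nc(C(F)(F)F)sc2N2CCN(C(=O)Cn3cnc4cccnc43)[C@H](C)C2)cn1`: 48 nM
compound 2 `CCOc1ncc(-c2nc(C(F)(F)F)sc2N2CCN(C(=O)Cn3ccc4cccnc43)[C@H](C)C2)cn1`: 47 nM
compound 3 `CCOc1ncc(-c2nc(C(F)(F)F)sc2N2CCN(C(=O)Cn3nccc3C)[C@H](C)C2)cn1`: 289 nM

Compound 3 gives the highest number of the three. The two steps reaching it, a 6.0-fold higher number from compound 1 to compound 3 (0.78 log units; beyond the scatter) and a 6.1-fold higher number from compound 2 to compound 3 (0.79 log units; beyond the scatter), both go beyond the scatter and both replace a fused bicyclic group with the single five-membered ring. Compound 1 and compound 2 sit within the scatter of each other, as a 1.0-fold lower number from compound 1 to compound 2 (0.01 log units; within the scatter) shows.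

Compound 4 `CCOc1ncc(-c2nc(C(F)(F)F)sc2N2CCN(C(=O)Cn3nc(C)cc3C)[C@H](C)C2)cn1` differs from compound 3 by methyl in place of hydrogen on an aromatic carbon. Among the compounds with values here, no measured step in this set concerns a methyl added to a ring of this kind: the steps recorded all exchange whole ring systems on the chain carbon next to the carbonyl, and none changes a single substituent on the five-membered ring. Within the data shown here, the only anchor is that compound 3 already carries one methyl on that ring and stands at 289 nM.

With nothing to push the number either way, the expected step of a 1.1-fold lower number from compound 3 to compound 4 (0.05 log units; within the scatter) is none beyond the scatter, and the estimate for compound 4 in this assay is 260 nM, with a range of 100 nM to 700 nM that leaves room for a modest shift in either direction.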

Compound 4, half-maximal inhibitory concentration: 60 nM
The estimate for compound 4 lay 4.3-fold (0.64 log units) above the measured number, outside the stated range (below it).
By their numbers in this assay, from the lowest: compounds 2, 1 and 4 (each within the scatter of the next); then compound 3.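

Going from 5-methyl-1H-pyrazol-1-yl to 3,5-dimethyl-1H-pyrazol-1-yl (a 4.8-fold lower number from compound 3 to compound 4 (0.68 log units; beyond the scatter)) in this assay shows that this aromatic carbon, two ring bonds from the ring atom that bears the large group, responds to the addition of a single heavy atom, something the whole-ring exchanges could not show. The single five-membered ring also no longer stands apart from the fused groups, since both a 1.3-fold higher number from compound 2 to compound 4 (0.11 log units; within the scatter) and a 1.3-fold higher number from compound 1 to compound 4 (0.10 log units; within the scatter) stay within the scatter, so among these compounds a fused bicyclic group is not required for numbers at this level, with compound 3 as the one monocyclic case that goes against this. No measurement at hand accounts for the size of the methyl step.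

Still open, going by these compounds, is whether the step is specific to methyl on this carbon or would also appear with ethyl, a chlorine atom, a nitrile or an amine there. Equally open, on these data alone, is how much the methyl on the ring atom two bonds away contributes, which a 3-methyl-1H-pyrazol-1-yl group in the same position would address.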